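This account rests on a few compounds, and the source may have more. Where it says the series, first, only, none or still open, it means among the compounds named here.

Among the measured compounds shown here, in a physicochemical assay for lipophilicity, read by HPLC, in phosphate buffer, measured as octanol-water partition, at pH 7.4, tested at 100 uM (a lower number here means a more polar compound, a higher number a more lipophilic compound), compound 2 `CCOc1ccc(-c2cccc(CNc3ccc(OCC(=O)O)c(F)c3)c2)c(C)c1` gives 2.83 and is the lower of the two numbers so far, while compound 1 `CCCOc1cc(C)c(-c2cccc(CNc3ccc(OCC(=O)O)c(F)c3)c2)c(C)c1` gives 3.59 and lies higher, beyond the scatter. Compound 3 `CCCOc1ccc(-c2cccc(CNc3ccc(OCC(=O)O)c(F)c3)c2)c(C)c1` follows from compound 2 through methyl in place of hydrogen on a saturated chain carbon, two bonds along the chain from an oxygen on an aromatic ring and so turns ethoxy to propoxy. For the measured compounds named here, no measured pair isolates this change, and compound 1 at 3.59 serves only as a loose point of comparison. A moderate upward move in this assay is expected, estimated as a number 0.37 log units higher from compound 2 to compound 3 (beyond the scatter) (a step likely near the edge of the scatter). For compound 3 the expected value is 3.2 with an estimated range from 2.9 to 3.6.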

Compound 3, distribution coefficient: 3.37
Compound 3: middle estimate off by 0.17 log units, on the low side; low and high end bracket the measured number.
By their numbers in this assay, from the lowest: compound 2; then compounds 3 and 1 (each within the scatter of the next).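

Ethoxy to propoxy now has a measured pair in this assay: methyl in place of hydrogen on a saturated chain carbon, two bonds along the chain from an oxygen on an aromatic ring, gives a number 0.54 log units higher from compound 2 to compound 3 (beyond the scatter) for this position. Hydrogen in place of methyl on an aromatic carbon gives a number 0.22 log units lower from compound 1 to compound 3 (within the scatter) in the second single-change pair, so that change leaves no step beyond the scatter here. Nothing available bears on a cause for either step. On these data alone, whether a longer chain such as butoxy, or an amine on that chain, would extend or reverse the step remains open.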